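Swapping a benzothiazole for a pyridine on the amide

A few compounds are considered here, and "the series" means these few. Any claim that something is new, unique, unknown or untested is made for them only; others in the source may bear on it.

Measured so far:
- compound 1, `Cc1c(NC(=O)COc2ccc(/C=C3\SC(=O)NC3=O)cc2)c(=O)n(-c2ccccc2)n1C`: < 100000 nM in a functional assay on Gurav cells (Homo sapiens) for cytotoxicity, read by sulforhodamine B assay, with a stated time of 48 h; a lower number here means a stronger inhibitor of growth, a higher number a weaker inhibitor of growth
- compound 2, `Cc1cnc(NC(=O)COc2ccc(/C=C3\SC(=O)NC3=O)cc2)s1`: 32400 nM; 195 nM (2 entries)
- compound 3, `O=C(COc1ccc(/C=C2\SC(=O)NC2=O)cc1)Nc1nc2ccccc2s1`: < 100000 nM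

Compound 3 has only a limit of this assay, not a number. The same limit appears for compound 1, while compound 2 shows two separate entries that sit far apart (the several entries of compound 2 in this assay, 32400 nM; 195 nM (2 entries)). Compound 4, `O=C(COc1ccc(/C=C2\SC(=O)NC2=O)cc1)Nc1ccccn1`, has not yet been measured. It differs from compound 3 by pyridin-2-yl in place of 1,3-benzothiazol-2-yl on an amide-type nitrogen. Given that two of the three values shown are limits the limit of < 100000 nM in this assay, at which 2 of the 3 values shown sit, and the third is split, no step from compound 3 to compound 4 can be read from the shown data; a weak inhibitor is expected, with a step that the limit leaves unreadable from compound 3 to compound 4. Compound 4 is estimated at 30000 nM, within 3000 nM to 100000 nM.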

Compound 4, concentration for 50% growth inhibition: < 100000 nM
Compound 4: only a limit was reported; the forecaster's own chance of this, stated with the estimate: 40%; the middle value does not contradict the limit.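

No step can be read from compound 3 to compound 4: in this assay each has only a limit, not a number. The compounds shown leave open whether pyridin-2-yl or 1,3-benzothiazol-2-yl on the amide-type nitrogen gives the stronger inhibitor of growth.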